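Oxadiazole hydroxamate and anilide pair: a methylene-linked analogue

This account rests on a few compounds, and the source may have more. Where it says the series, first, only, none or still open, it means among the compounds named here.

Compound 1 `O=C(NO)c1ccc(-c2nnc(Cc3cccc4ccccc34)o2)cc1`, in an assay on isolated protein for inhibition of histone deacetylase 4 (Homo sapiens), read by fluorescence, with a stated time of 15 min; on this read-out lower numbers stand for stronger inhibition and higher numbers for weaker inhibition: > 20000 nM, a limit of the assay.
Compound 2 `Nc1ccccc1NC(=O)c1ccc(Cc2nnc(Cc3cccc4ccccc34)o2)cc1`, in this assay: > 20000 nM, also a limit of the assay.

Compound 2 stands at the limit, as the limit of > 20000 nM in this assay, at which 2 of the 2 values shown sit, shows. Compound 3 `O=C(NO)c1ccc(Cc2nnc(Cc3cccc4ccccc34)o2)cc1` differs from compound 2 by hydroxy in place of 2-aminophenyl on an amide-type nitrogen. Among the measured compounds shown here, compound 1, which also carries the hydroxycarbamoyl group, sits at the limit as well, so no measured step points in either direction. The step from compound 2 to compound 3 is expected to be a number no higher from compound 2 to compound 3 (the limit leaves the size open), none beyond the scatter. Compound 3 is therefore estimated at 20000 nM, within 3000 nM to 60000 nM.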

Compound 3, half-maximal inhibitory concentration: 7800 nM
Estimate against measurement, compound 3: 2.6-fold (0.41 log units) above, within the range that was stated.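

In this assay, hydroxy in place of 2-aminophenyl on an amide-type nitrogen gives an at least 2.5-fold lower number from compound 2 to compound 3 (0.40 log units; beyond the scatter), so this position responds to the change, and compound 3 is the only compound shown whose value is not a limit. Compound 1, which also carries the hydroxycarbamoyl group, gives > 20000 nM, a limit of the assay, so this group alone does not guarantee a measurable value. The full size of the step stays unknown: the limit of > 20000 nM in this assay, at which 2 of the 3 values shown sit.

As far as these compounds go, what a methoxy group or a plain amine on this nitrogen would give stays open. So does the effect of a carboxylic acid in place of the hydroxycarbamoyl group.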